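The compounds below may be only part of what the source reports. "The series", "measured", "known", "first", "only" and "open" are said of these compounds alone.

In a functional assay on PC-3 cells (Homo sapiens) for inhibition, read by MTT assay, with a stated time of 48 h, tested at 10 uM (a higher number here means more inhibition of growth at the concentration tested, a lower number less inhibition of growth), compound 1 `CN1CC[C@H](c2c(O)cc(O)c3c(=O)cc(/C=C/c4ccccc4)oc23)[C@H](O)C1`, which carries a phenyl group on the double-bonded chain, gives 10%. Compound 2 `CN1CC[C@H](c2c(O)cc(O)c3c(=O)cc(/C=C/c4ccc(Cl)cc4)oc23)[C@H](O)C1`, with a 4-chlorophenyl group there, gives 12%. Compound 3 `CN1CC[C@H](c2c(O)cc(O)c3c(=O)cc(/C=C/c4c(F)c(F)c(F)c(F)c4F)oc23)[C@H](O)C1`, with 2,3,4,5,6-pentafluorophenyl in that place, stands highest of the three at 82%.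

Compound 4 `CN1CC[C@H](c2c(O)cc(O)c3c(=O)cc(/C=C/c4ccccc4F)oc23)[C@H](O)C1` has not yet been measured. The change from the leader is 2-fluorophenyl in place of 2,3,4,5,6-pentafluorophenyl on a double-bonded chain carbon bound to a double-bonded chain carbon. Within the data shown here, no compound with a single fluorine has been tested, so the evidence is indirect. Among the measured compounds shown here, three measured steps bear on it. The step with one chloro added is small: a number 2 percentage points higher from compound 1 to compound 2 (within the scatter). The two steps that bring in the pentafluorophenyl group are large: a number 72 percentage points higher from compound 1 to compound 3 (beyond the scatter) and a number 70 percentage points higher from compound 2 to compound 3 (beyond the scatter). Compound 4 gives up that group and keeps one halogen on the ring, so it looks closer to compound 2 than to compound 3.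

The expected step is large and downward, a number 64 percentage points lower from compound 3 to compound 4 (beyond the scatter). For compound 4 the estimated value is 18%, with an expected range from 4% to 45%.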

Compound 4, percent growth inhibition at one concentration: 25%
Compound 4: the middle estimate sits 7 percentage points below what was measured; low and high end bracket the measured number.
By their numbers in this assay, from the lowest: compounds 1 and 2 (each within the scatter of the next); then compound 4; then compound 3.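

In this assay, a single fluoro on the ring does shift the result, unlike the chloro step seen earlier: fluoro in place of hydrogen gives a number 15 percentage points higher from compound 1 to compound 4 (beyond the scatter) and 2-fluorophenyl in place of 4-chlorophenyl gives a number 13 percentage points higher from compound 2 to compound 4 (beyond the scatter) at this place on the double-bonded chain. Even so, one fluorine recovers only a small part of the pentafluorophenyl effect, with 2-fluorophenyl in place of that group giving a number 57 percentage points lower from compound 3 to compound 4 (beyond the scatter) in the same assay. Nothing available here explains why these ring changes differ in size.

On these data alone, it remains open whether the number climbs gradually between one fluorine and five, as a difluorophenyl or trifluorophenyl group could show. The same holds for whether a trifluoromethyl, nitrile or methoxy group on this ring would behave like fluoro.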